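The source may hold more compounds than are shown below. What is called first, only, known or untested is meant among the compounds shown, and "the series" means these compounds.

Compound 1 `Cc1n[nH]cc1-c1cccc2c1CCC2c1ncc[nH]1` gives 91% in a functional assay on CHO cells for agonist activity at Alpha-1A adrenergic receptor (Homo sapiens), read by FLIPR and calcium flux (a higher number here means a larger maximal response, a lower number a smaller maximal response), the highest of the three numbers measured. Compound 3 `CS(=O)(=O)Nc1cccc2c1CCC2c1ncc[nH]1` stands nearest to it with 87%, and compound 2 `Cn1ccc(-c2cccc3c2CCC3c2ncc[nH]2)n1` furthest with 19%. The two measured steps from compound 1 are a number 4 percentage points lower from compound 1 to compound 3 (within the scatter) and a number 72 percentage points lower from compound 1 to compound 2 (beyond the scatter). Compound 4 `Cc1oncc1-c1cccc2c1CCC2c1ncc[nH]1` arises from compound 1 through (5-methyl-1,2-oxazol-4-yl in place of 3-methyl-1H-pyrazol-4-yl on an aromatic carbon). The step that bears most on this change is the large fall seen in a number 72 percentage points lower from compound 1 to compound 2 (beyond the scatter), where the hydrogen-bond donor of the ring was also given up, whereas the change to compound 3 kept a donor. A drop beyond the scatter is therefore expected, though smaller, with considerable uncertainty: compound 4 is estimated at 50%, between 15% and 90%, a step of a number 41 percentage points lower from compound 1 to compound 4 (beyond the scatter).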

Compound 4, largest response reached (Emax), in percent of the reference or control that the assay uses: 63%
Compound 4: middle estimate off by 13 percentage points, on the low side; the range from low to high includes it.
By their numbers in this assay, from the lowest: compound 2; then compound 4; then compounds 3 and 1 (each within the scatter of the next).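

With no hydrogen-bond donor, the 5-methyl-1,2-oxazol-4-yl group gives a number 28 percentage points lower from compound 1 to compound 4 (beyond the scatter) and a number 24 percentage points lower from compound 3 to compound 4 (beyond the scatter), so at this aromatic carbon both donor-bearing groups stand above it. Yet it also gives a number 44 percentage points higher from compound 2 to compound 4 (beyond the scatter), so two groups without a donor can still differ widely, and the donor count alone does not set the response. Nothing measured here explains these differences. From the compounds shown here alone, it remains open how a simple amine or an unmethylated 1H-pyrazol-4-yl would behave at this position in this assay.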